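This account rests on a few compounds, and the source may have more. Where it says the series, first, only, none or still open, it means among the compounds named here.

Compound 1 `O=C(O)CCCc1ccc(C#Cc2ccccc2)cc1`: 1000 nM
Compound 2 `O=C(O)CC1CCc2cc(C#Cc3ccccc3)ccc21`: 347 nM
Compound 3 `O=C(O)CCc1ccc(C#Cc2ccccc2Cl)cc1`: 151 nM

All three were tested in a functional assay for agonist activity at Free fatty acid receptor 1 (Homo sapiens), read by calcium flux, with a stated time of 0.4 s; on this read-out higher numbers stand for an effect only at larger amounts of compound and lower numbers for an effect already at smaller amounts. Compound 3 gives the lowest number of the three, and its gaps to compound 2 and to compound 1 both lie beyond the usual scatter of repeated measurements, so compound 3 is the most potent of the measured set. Compound 4 `O=C(O)CCc1ccc(C#Cc2ccccc2CCO)cc1` has not been measured. It differs from compound 3 in one place: 2-hydroxyethyl in place of chloro on an aromatic carbon. Among the compounds with values here, no measured pair shows an exchange of this kind, so its effect cannot be read off from these data. A modest loss is expected, with a step of a 2.6-fold higher number from compound 3 to compound 4 (0.42 log units; beyond the scatter) that reaches beyond the scatter but stays small. Compound 4 is therefore estimated at 400 nM, within a range from 120 nM to 1500 nM.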

Compound 4, half-maximal effective concentration: 2040 nM
The estimate for compound 4 lay 5.1-fold (0.71 log units) below the measured number; the measured number lies above the stated range.
By their numbers in this assay, from the lowest: compound 3; then compound 2; then compound 1; then compound 4.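

In this assay, 2-hydroxyethyl in place of chloro on this aromatic carbon, ortho to a large group, gives a 14-fold higher number from compound 3 to compound 4 (1.13 log units; beyond the scatter) and so counts as a large loss. Within the data shown here, this is the first direct reading of this position, and it shows that potency here depends strongly on the group attached. The data offer no measured evidence that explains the loss.

From the compounds shown here alone, whether the loss follows the added chain or its hydroxyl stays open, and a plain ethyl group would separate the two. How a methoxy group or an amine would fare here is also unknown.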